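Swapping one thiazole isomer for another on the shared core

A few compounds are considered here, and "the series" means these few. Any claim that something is new, unique, unknown or untested is made for them only; others in the source may bear on it.

Values in a physicochemical assay for solubility, in phosphate buffer, with a stated time of 18 h, at pH 7; a lower number here means a less soluble compound, a higher number a more soluble compound:
- Compound 1 `CC(C)CN1C(=O)c2ccccc2[C@H](C(=O)Nc2ccc(F)c(C#N)c2)[C@H]1c1ccsc1`: < 1000 nM (a limit)
- Compound 2 `CC(C)CN1C(=O)c2ccccc2[C@H](C(=O)Nc2ccc(F)c(C#N)c2)[C@H]1c1cncs1`: 63000 nM

Going by the values given here, compound 2 carries the only actual number in this small set, 63000 nM. Compound 1 reads < 1000 nM, which is a limit of the assay and not a number. Among the compounds with values here, the one measured step is an at least 63-fold higher number from compound 1 to compound 2 (1.79 log units; beyond the scatter), and it is large.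

The next compound is compound 3 `CC(C)CN1C(=O)c2ccccc2[C@H](C(=O)Nc2ccc(F)c(C#N)c2)[C@H]1c1cnsc1`, which places 1,2-thiazol-4-yl where compound 2 has 1,3-thiazol-5-yl, on a saturated ring carbon of the shared core: 1,2-thiazol-4-yl in place of 1,3-thiazol-5-yl on a saturated ring carbon. The same atoms are simply joined differently. Within the data shown here, the measured step is only a loose guide because an at least 63-fold higher number from compound 1 to compound 2 (1.79 log units; beyond the scatter) is the sole step available, and it began from thiophen-3-yl rather than from a ring of the kind exchanged here. Among the measured compounds shown here, a much smaller move in this assay is therefore expected, leaning slightly downward, though no measurement yet fixes its direction. The expected change is a 2.1-fold lower number from compound 2 to compound 3 (0.32 log units; beyond the scatter). For compound 3 the estimated value is 30000 nM, with an expected range from 4000 nM to 120000 nM.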

Compound 3, solubility: 20000 nM
Compound 3: middle estimate off by 1.5-fold (0.18 log units), on the high side, and the stated range covers the measured number.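

Rejoining the same atoms within the five-membered ring is enough to shift the number in this assay: the exchange gives a 3.2-fold lower number from compound 2 to compound 3 (0.50 log units; beyond the scatter), a modest step, so the two thiazole isomers on this saturated ring carbon are not interchangeable here. Both isomers nevertheless keep most of the large rise seen on leaving the thiophene, as replacing thiophen-3-yl with 1,2-thiazol-4-yl gives an at least 20-fold higher number from compound 1 to compound 3 (1.30 log units; beyond the scatter), so among the compounds shown that rise is not confined to a single arrangement of the ring atoms. Compound 1 reads < 1000 nM, which is a limit and not a number, and the true size of both steps from it stays unknown because of that limit: the limit of < 1000 nM in this assay, at which 1 of the 3 values shown sits.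

The compounds shown leave open whether other rings on this carbon, such as 1,3-thiazol-2-yl or pyridin-3-yl, would fall with the two thiazoles or with the thiophene. They also leave open whether the order of the two isomers would hold with a longer chain, or a chain ending in an amine, in place of the isobutyl group.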